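The compounds below may be only part of what the source reports. "The series", "measured", "known", "first", "only" and "open" are said of these compounds alone.

In a functional assay on NCI-H460 cells (Homo sapiens) for antiproliferative activity, read by MTT assay, with a stated time of 48 h (on this read-out lower numbers stand for stronger inhibition and higher numbers for weaker inhibition), compound 3 `COc1cc(-c2cccc3nc(-c4ccc(C)cc4)oc23)cc(OC)c1OC` gives 1900 nM, and compound 1 `COc1cc(-c2cccc3nc(-c4cccc(F)c4)oc23)cc(OC)c1OC` gives 3300 nM. These two stand level, since a 1.7-fold lower number from compound 1 to compound 3 (0.24 log units; within the scatter) is no real difference. Compound 2 `COc1cc(-c2cccc3nc(-c4ccc(Cl)cc4)oc23)cc(OC)c1OC` reports only a limit, > 25000 nM. Measured against that limit, the other two compounds are clearly separated from it, with an at least 7.5-fold higher number from compound 1 to compound 2 (0.87 log units; beyond the scatter) and an at least 13-fold lower number from compound 2 to compound 3 (1.11 log units; beyond the scatter).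

Compound 4 `COc1cc(-c2cccc3nc(-c4cccc(O)c4)oc23)cc(OC)c1OC` carries 3-hydroxyphenyl in place of 4-methylphenyl (3-hydroxyphenyl in place of 4-methylphenyl on an aromatic carbon), on an aromatic carbon of the five-membered aromatic ring, next to the ring nitrogen and next to the ring oxygen. Within the data shown here, no measured compound carries this group. The closest guide is compound 1, whose 3-fluorophenyl keeps it level with compound 3 in a 1.7-fold lower number from compound 1 to compound 3 (0.24 log units; within the scatter), so a group at that place on the ring need not cost much. The large steps to compound 2 show, however, that a single change can cost a great deal, so the range stays wide and leans towards higher numbers.

The expected change is a 1.6-fold higher number from compound 3 to compound 4 (0.20 log units; within the scatter), so no step beyond the scatter is anticipated. Compound 4 is estimated at 3000 nM, with an expected range of 700 nM to 13000 nM.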

Compound 4, half-maximal inhibitory concentration: 1900 nM
Estimate against measurement, compound 4: 1.6-fold (0.20 log units) above; measured number inside the range.
By their numbers in this assay, from the lowest: compounds 3, 4 and 1 (each within the scatter of the next). At a limit, above all of these: compound 2.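

In this assay, 3-hydroxyphenyl on this aromatic carbon of the five-membered ring gives no change at the digits printed from compound 3 to compound 4 (within the scatter), so a group with a hydrogen-bond donor stands level with 4-methylphenyl, which has none. On the same phenyl position, hydroxy in place of fluoro gives a 1.7-fold lower number from compound 1 to compound 4 (0.24 log units; within the scatter), which places compounds 1, 3 and 4 within the scatter of one another, with only compound 2 going against this picture. The gap to that compound, an at least 13-fold lower number from compound 2 to compound 4 (1.11 log units; beyond the scatter), rests on a limit rather than a number: the limit of > 25000 nM in this assay, at which 1 of the 4 values shown sits.

Whether the loss in compound 2 goes with the chloro group itself or with its place on the phenyl ring stays open, as the compounds shown include neither 3-chlorophenyl nor 4-hydroxyphenyl. Going by these compounds, it is also open whether an amine or a carboxylic acid on this phenyl ring would stay level with compound 4.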